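Working notes: from compound 2 to compound 3

A few compounds are considered here, and "the series" means these few. Any claim that something is new, unique, unknown or untested is made for them only; others in the source may bear on it.

Measured in a functional assay on CCRF-CEM cells (Homo sapiens) for inhibition, read by MTT assay, with a stated time of 72 h; a lower number here means a stronger inhibitor, a higher number a weaker inhibitor:
- compound 1 `COc1cccc(/C=C/C(=O)Nc2cc(OC)c(OC)c(OC)c2)c1`: 23400 nM
- compound 2 `C=C(Br)C(=O)Nc1cccc(/C=C/C(=O)Nc2cccc(F)c2)c1`: 26000 nM

Only these two values are available so far, and they lie within the usual scatter of each other. Compound 2, at 26000 nM, therefore cannot be separated from compound 1 at 23400 nM, although the two structures differ in several places. Among the measured compounds shown here, no measured pair differs in one place, so the data do not size any single structural change.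

Compound 3 `C=C(Br)C(=O)Nc1cccc(/C=C/C(=O)NCc2ccc(C)cc2)c1` has not yet been measured in this assay. It carries 4-methylbenzyl in place of 3-fluorophenyl on an amide-type nitrogen. The rest of the structure of compound 2 is kept.

For the measured compounds named here, with no measured step as a guide, the expectation rests on the value of compound 2, 26000 nM, and its direction is tentative. The expected change is modest, toward a lower number, and may not exceed the scatter: the estimated step is a 2.2-fold lower number from compound 2 to compound 3 (0.34 log units; beyond the scatter). For compound 3 the estimated value is 12000 nM, with an expected range of 2500 nM to 50000 nM.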

Compound 3, half-maximal inhibitory concentration: 550 nM
Estimate against measurement, compound 3: 22-fold (1.34 log units) above; the whole stated range lies above it.
By their numbers in this assay, from the lowest: compound 3; then compounds 1 and 2 (each within the scatter of the next).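

In this assay, among the compounds shown here, 4-methylbenzyl in place of 3-fluorophenyl on the amide-type nitrogen gives a 47-fold lower number from compound 2 to compound 3 (1.67 log units; beyond the scatter), the first step that can be assigned to one place, and it shows that this place can carry a large change in the read-out while the rest of compound 2 is kept. The exchange is a single step but a composite one: the entering group has a carbon-containing link to the nitrogen and a methyl, whereas the leaving group has the aromatic ring directly on the nitrogen and a fluorine, and the step cannot divide its size among these differences. Nothing measured here gives a reason for the size of this step.

Going by these compounds, it remains open how much of the step follows the benzyl link alone and how much follows the methyl, a question that plain benzyl and 4-methylphenyl at the same nitrogen would address. Also open, on these data alone, is how the read-out responds to a longer chain such as 2-phenylethyl, or to a carboxylic acid or an amine on the aromatic ring of this group.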